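The source may hold more compounds than are shown below. What is called first, only, known or untested is meant among the compounds shown, and "the series" means these compounds.

Values in a functional assay on SW-620 cells (Homo sapiens) for cytotoxicity, read by MTT assay, with stated times of 4 h and 72 h, tested at 5 uM; a lower number here means a stronger inhibitor, a higher number a weaker inhibitor:
- compound 1 `Cc1cc(Nc2ccc(C(=O)/C=C/c3ccc4ccccc4c3)cc2)n2nc(SCc3cccc(Br)c3)nc2n1`: 270 nM
- compound 2 `Cc1cc(Nc2ccc(C(=O)/C=C/c3ccc4ccccc4c3)cc2)n2nc(SCc3ccc(Cl)cc3)nc2n1`: 570 nM
- compound 3 `Cc1cc(Nc2ccc(C(=O)/C=C/c3ccc4ccccc4c3)cc2)n2nc(SCc3ccc([N+](=O)[O-])cc3)nc2n1`: 1130 nM

Compound 3 sits at the upper end of these numbers, and the gap to its nearest neighbour is small: a 2.0-fold higher number from compound 2 to compound 3 (0.30 log units; within the scatter). The gap to the remaining compound is wider: a 4.2-fold higher number from compound 1 to compound 3 (0.62 log units; beyond the scatter).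

The next compound is compound 4 `Cc1cc(Nc2ccc(C(=O)/C=C/c3ccc4ccccc4c3)cc2)n2nc(SCc3ccccc3)nc2n1`, which carries hydrogen in place of nitro on an aromatic carbon. No benzyl without a ring substituent has been measured, so only exchanges of the ring substituent bear on this change. Those exchanges have been modest at most, and the other one measured is a 2.1-fold higher number from compound 1 to compound 2 (0.32 log units; beyond the scatter). Compound 2, which carries chloro at the same place, gives 570 nM, so the exchange there has moved the number little.

The expected change is small, leaning towards a lower number and close to the scatter: a 1.6-fold lower number from compound 3 to compound 4 (0.21 log units; within the scatter) is the estimated step. For compound 4 the estimated value is 700 nM, with an expected range of 250 nM to 2000 nM.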

Compound 4, half-maximal inhibitory concentration: 300 nM
Beside the measured number, compound 4's estimate is 2.3-fold (0.37 log units) above it; measured number inside the range.
By their numbers in this assay, from the lowest: compounds 1, 4, 2 and 3 (each within the scatter of the next, the first and the last beyond it).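

Removing the ring substituent gives, in this assay, a step beyond the scatter only against nitro: a 3.8-fold lower number from compound 3 to compound 4 (0.58 log units; beyond the scatter). Against the halogens the steps stay within the scatter, a 1.9-fold lower number from compound 2 to compound 4 (0.28 log units; within the scatter) and a 1.1-fold higher number from compound 1 to compound 4 (0.05 log units; within the scatter), so neither chloro nor bromo is separated from the plain benzylsulfanyl, and no substituent on this ring is needed to reach the level of compound 1. Nothing measured here accounts for the higher number of the 4-nitrobenzyl compound.

As far as these compounds go, whether that higher number is particular to nitro remains open, since compound 2 sits within the scatter of compound 3 and of compound 4, and an amine, a methoxy group or a carboxylic acid on this aromatic carbon could test it. From the compounds shown here alone, the effect of a phenethyl group in place of benzyl on the sulfur also remains open.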